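This account rests on a few compounds, and the source may have more. Where it says the series, first, only, none or still open, it means among the compounds named here.

Of the compounds shown here, two have numbers so far. Compound 1 `O=C(O)c1cncc(C2CC2c2ccc(OCc3c(-c4c(Cl)cccc4Cl)noc3C3CC3)cc2Cl)c1` gives 14 nM in an assay on HEK293 cells for agonist activity at Bile acid receptor (Homo sapiens); a lower number here means that less compound is needed, a higher number that more compound is needed for the effect. Compound 2 `CO[C@]1(c2ccc(OCc3c(-c4c(Cl)cccc4Cl)noc3C3CC3)cc2Cl)C[C@H](c2cccc(C(=O)O)c2)C1` gives 102 nM in this assay, the higher of the two numbers, with compound 1 lying below it beyond the scatter.

Compound 3 `CCO[C@]1(c2ccc(OCc3c(-c4c(Cl)cccc4Cl)noc3C3CC3)cc2Cl)C[C@H](c2cccc(C(=O)O)c2)C1` is not yet measured. It differs from compound 2 in one place: methyl in place of hydrogen on a saturated chain carbon bound to an oxygen on a saturated carbon. Going by the values given here, no measured pair shows a step of this kind, so the direction is open; the change is small and the step is expected to stay within the scatter, a 1.1-fold higher number from compound 2 to compound 3 (0.03 log units; within the scatter). For compound 3 the estimate in this assay is 110 nM, between 45 nM and 270 nM.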

Compound 3, half-maximal effective concentration: 220 nM
Estimate against measurement, compound 3: 2.0-fold (0.30 log units) below; the measured number falls inside the stated range.
By their numbers in this assay, from the lowest: compound 1; then compound 2; then compound 3.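

Going from methoxy to ethoxy gives a 2.2-fold higher number from compound 2 to compound 3 (0.33 log units; beyond the scatter) in this assay and is the first step read at this position. A single added methyl on the saturated chain carbon bound to the oxygen is enough to move the number beyond the scatter, so this position does not tolerate the change without a loss. No available data account for this step.

As far as these compounds go, a single step gives a direction but no trend, so it remains open whether a longer chain such as propoxy would raise the number further. From the compounds shown here alone, it also remains open whether a hydroxyl in place of the methoxy would lower it.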